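Swapping the halogenated phenyl on the triazole of compound 3

The source may hold more compounds than are shown below. What is called first, only, known or untested is meant among the compounds shown, and "the series" means these compounds.

Measured compounds:
Compound 1 `O=c1[nH]cc(S(=O)(=O)Nc2cccc(-c3cn(-c4ccccc4Cl)nn3)c2)c(=O)[nH]1` — 5370 nM
Compound 2 `Cc1ccccc1-n1cc(-c2ccc(NS(=O)(=O)c3c[nH]c(=O)[nH]c3=O)cc2)nn1` — 7310 nM
Compound 3 `O=c1[nH]cc(S(=O)(=O)Nc2ccc(-c3cn(-c4cccc(F)c4)nn3)cc2)c(=O)[nH]1` — > 20000 nM

In a functional assay on OVCAR-3 cells (Homo sapiens) for antiproliferative activity, read by MTT assay, with a stated time of 24 h (a higher number here means a weaker inhibitor, a lower number a stronger inhibitor), compound 1 gives 5370 nM and compound 2 gives 7310 nM. Compound 3 returns only a limit of the assay, > 20000 nM, so its place among the three is known only as the weakest end of what was seen, with the limit of > 20000 nM in this assay, at which 1 of the 3 values shown sits, marking that one value sits at that boundary. Among the measured compounds shown here, the single measured step that touches compound 3 is an at least 2.7-fold higher number from compound 2 to compound 3 (0.43 log units; beyond the scatter), a worsening on exchanging one phenyl for another on the triazole nitrogen.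

Compound 4 `O=c1[nH]cc(S(=O)(=O)Nc2ccc(-c3cn(-c4ccc(Cl)cc4)nn3)cc2)c(=O)[nH]1` differs from compound 3 by 4-chlorophenyl in place of 3-fluorophenyl on an aromatic nitrogen. For the measured compounds named here, no measured step reports this particular exchange, and the starting point is a limit rather than a number, so the direction of an at least 1.3-fold lower number from compound 3 to compound 4 (0.12 log units; that floor lies within the scatter) is expected only loosely; the values of compound 1 and compound 2 suggest that a halogenated phenyl at this position can return a number. Compound 4 is therefore estimated at 15000 nM, within 5000 nM to 40000 nM.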

Compound 4, half-maximal inhibitory concentration: 2160 nM
Compound 4: middle estimate off by 6.9-fold (0.84 log units), on the high side; the whole stated range lies above it.
By their numbers in this assay, from the lowest: compound 4; then compounds 1 and 2 (each within the scatter of the next). At a limit, above all of these: compound 3.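

Among the compounds shown here, with 4-chlorophenyl on the aromatic nitrogen, this assay records a 3.4-fold lower number from compound 2 to compound 4 (0.53 log units; beyond the scatter), so a change at this position can lower the number on this core, which the one earlier step, a rise, did not show. Against 3-fluorophenyl, the same group gives an at least 9.2-fold lower number from compound 3 to compound 4 (0.96 log units; beyond the scatter), so two halogenated phenyls at one place on one core can end up far apart, and the presence of a halogen alone does not settle the outcome. Compound 3 holds only a limit of the assay, which makes that step a floor rather than a measured size: the limit of > 20000 nM in this assay, at which 1 of the 4 values shown sits.

From the compounds shown here alone, the exchange alters the halogen and its place on the phenyl together, so 3-chlorophenyl and 4-fluorophenyl remain open as the groups that would separate the two. Also open, going by these compounds, is what a phenyl bearing an amine or a carboxylic acid would return here.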